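A few compounds are considered here, and "the series" means these few. Any claim that something is new, unique, unknown or untested is made for them only; others in the source may bear on it.

Compound 2 `O=S(=O)(NCCCNCc1ccccc1)c1cc(C(F)(F)F)cc(C(F)(F)F)c1` carries the lowest number of the two compounds measured; in a functional assay on BE(2)-C cells (Homo sapiens) for inhibition, read by MTT assay, with a stated time of 72 h (on this read-out higher numbers stand for weaker inhibition of growth and lower numbers for stronger inhibition of growth), compound 2 gives 12000 nM. Its nearest neighbour, compound 1 `O=S(=O)(NCCCNCc1ccccc1Cl)c1cc(C(F)(F)F)cc(C(F)(F)F)c1`, gives 15000 nM in this assay, and the step of a 1.3-fold lower number from compound 1 to compound 2 (0.10 log units; within the scatter), hydrogen in place of chloro on an aromatic carbon, stays within the scatter. Compound 3 `O=S(=O)(NCCCNCc1ccc(Br)cc1)c1cc(C(F)(F)F)cc(C(F)(F)F)c1` differs from compound 2 by bromo in place of hydrogen on an aromatic carbon. Within the data shown here, the only measured step touching a halogen on this ring, that from compound 1 to compound 2, was small, so no movement beyond the scatter is expected in this assay. Compound 3 is therefore estimated at 12000 nM, within a range of 5000 nM to 30000 nM, an expected step of no change at the digits printed from compound 2 to compound 3 (within the scatter).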

Compound 3, concentration for 50% growth inhibition: 2700 nM
Estimate against measurement, compound 3: 4.4-fold (0.65 log units) above; measured number below the stated range.
By their numbers in this assay, from the lowest: compound 3; then compounds 2 and 1 (each within the scatter of the next).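

Bromo on an aromatic carbon, para to a large group, moves the number beyond the scatter in this assay, with a 4.4-fold lower number from compound 2 to compound 3 (0.65 log units; beyond the scatter), whereas the earlier chloro-to-hydrogen change on this ring did not. The wider change, 4-bromophenyl in place of 2-chlorophenyl, gives a 5.6-fold lower number from compound 1 to compound 3 (0.74 log units; beyond the scatter), so a halogen on this ring does not leave the number unchanged in every case. Nothing shown accounts for this shift.

Compound 1 and compound 3 differ in both the halogen and its place on the ring, so the compounds shown do not separate these two changes. From the compounds shown here alone, how a 4-chlorophenyl or a 4-methoxyphenyl group would read in this assay remains open.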